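This account rests on a few compounds, and the source may have more. Where it says the series, first, only, none or still open, it means among the compounds named here.

Measured so far:
compound 1, `CC1=NC(C)=C(C(=O)O)C(c2cccc(C(=O)O)c2)/C1=C(\O)OC/C=C/c1ccccc1`: 37000 nM
compound 2, `CC1=NC(C)=C(C(=O)O)C(c2cccc(Cl)c2)/C1=C(\O)OC/C=C/c1ccccc1`: 1000 nM

In a functional assay on IMR-32 cells for inhibition of Voltage-dependent N-type calcium channel subunit alpha-1B (Homo sapiens), read by calcium flux (on this read-out lower numbers stand for stronger inhibition and higher numbers for weaker inhibition), compound 1 stands highest of the two numbers, with compound 2 the nearest. For the measured compounds named here, the single change separating them, a 37-fold lower number from compound 1 to compound 2 (1.57 log units; beyond the scatter), was a large step. Compound 3, `CC1=NC(C)=C(C(=O)O)C(c2cccc(Br)c2)/C1=C(\O)OC/C=C/c1ccccc1`, differs from compound 1 by bromo in place of carboxy on an aromatic carbon. Bromo, like chloro, is a halogen, and it takes the same place that chloro takes in compound 2, so the measured step from compound 1 to compound 2 is the one that bears here, and a drop of similar size in this assay is expected. Compound 3 is therefore expected to give 1000 nM, between 300 nM and 3500 nM, a step of a 37-fold lower number from compound 1 to compound 3 (1.57 log units; beyond the scatter).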

Compound 3, half-maximal inhibitory concentration: 790 nM
For compound 3 the middle estimate is 1.3-fold (0.10 log units) above the measured one; the measured number falls inside the stated range.
By their numbers in this assay, from the lowest: compounds 3 and 2 (each within the scatter of the next); then compound 1.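

In this assay, bromo in place of carboxy also gives a large step (a 47-fold lower number from compound 1 to compound 3 (1.67 log units; beyond the scatter)), so the large step seen with chloro is not confined to that one halogen. The step between the two halogens (a 1.3-fold lower number from compound 2 to compound 3 (0.10 log units; within the scatter)) lies within the scatter, so this read-out does not separate compound 2 from compound 3. Nothing available here explains why either halogen differs so much from carboxy. Open still is where fluoro or iodo would fall at this place on the ring. Open too, going by these compounds, is whether a non-halogen group, such as methyl, methoxy or an amine, would read like the halogens or like carboxy.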